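The source may report more compounds than this note shows. Statements on the series, on what has been measured and on what is new or still open speak of the compounds shown alone.

In an ADME assay on MT4 cells (Homo sapiens) for cytotoxicity, read by MTT assay, with a stated time of 5 days (a higher number here means that more compound is tolerated, a lower number that less compound is tolerated), compound 1 `Cc1cc(C)cc(S(=O)(=O)c2c(C(=O)N[C@@H]3CCNC3)[nH]c3ccc(Cl)cc23)c1` gives 37300 nM. Compound 2 `Cc1cc(C)cc(S(=O)(=O)c2c(C(=O)N[C@@H]3CCN(CC(N)=O)C3)[nH]c3ccc(Cl)cc23)c1` gives 31000 nM. Compound 3 `Cc1cc(C)cc(S(=O)(=O)c2c(C(=O)NC3CN(Cc4ccccc4C#N)C3)[nH]c3ccc(Cl)cc23)c1` stands at > 234000 nM, which is a limit and not a number. Compound 4 `Cc1cc(C)cc(S(=O)(=O)c2c(C(=O)NC3CN(Cc4ccccc4F)C3)[nH]c3ccc(Cl)cc23)c1` carries fluoro in place of cyano on an aromatic carbon, ortho to a large group: fluoro in place of cyano on an aromatic carbon. Among the compounds with values here, the one measured step, a 1.2-fold lower number from compound 1 to compound 2 (0.08 log units; within the scatter), places carbamoylmethyl on an amine nitrogen in a ring, so it bears only loosely on this change, and it shows no movement beyond the scatter. Within the data shown here, with no measured step at this place, only a modest downward step or none is expected, and a limit reading remains likely. The estimated step is an at least 1.5-fold lower number from compound 3 to compound 4 (0.19 log units; that floor lies within the scatter). For compound 4 the expected value is 150000 nM, with an expected range of 50000 nM to 240000 nM.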

Compound 4, half-maximal cytotoxic concentration: > 238000 nM
Compound 4 was reported as a limit; the forecaster's own chance of this, stated with the estimate: 55%; middle value at least 1.5-fold (0.20 log units) from the limit.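

In this assay compound 4 is reported as a limit and not a number: the limit of > 238000 nM in this assay, at which 1 of the 4 values shown sits. Compound 3 is also a limit and not a number: the limit of > 234000 nM in this assay, at which 1 of the 4 values shown sits. The step between these two cannot be read, but 1-(2-fluorobenzyl)azetidin-3-yl on the amide-type nitrogen gives an at least 7.6-fold higher number from compound 2 to compound 4 (0.88 log units; beyond the scatter) and an at least 6.3-fold higher number from compound 1 to compound 4 (0.80 log units; beyond the scatter).

From the compounds shown here alone, whether fluoro and cyano at this place differ at all remains open. Also open, going by these compounds, is what a methoxy group or an amine in place of fluoro would give.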